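Adding a hydroxy group to an anilide inhibitor of malate dehydrogenase

The source may hold more compounds than are shown below. What is called first, only, known or untested is meant among the compounds shown, and "the series" means these compounds.

Of the compounds shown here, three have been tested in an assay on isolated protein for inhibition of malate dehydrogenase, mitochondrial (Homo sapiens), with a stated time of 30 min; on this read-out higher numbers stand for weaker inhibition and lower numbers for stronger inhibition. Compound 1 `COC(=O)c1ccc(O)c(NC(=O)CCCOc2ccc(C(C)(C)CC(C)(C)C)cc2)c1` gives 1110 nM. Compound 2 `CC(C)(C)CC(C)(C)c1ccc(OCC(=O)N2CCN(Cc3ccc(C(F)(F)F)cc3)CC2)cc1` gives 5400 nM. Compound 3 `COC(=O)c1cccc(NC(=O)C(C)(C)Oc2ccc(C(C)(C)CC(C)(C)C)cc2)c1` gives 1320 nM, the second highest of the three numbers; the value of compound 1 lies within the scatter of it, while compound 2 gives a clearly higher number, beyond the scatter. Compound 4 `COC(=O)c1ccc(O)c(NC(=O)C(C)(C)Oc2ccc(C(C)(C)CC(C)(C)C)cc2)c1` differs from compound 3 in one place: hydroxy in place of hydrogen on an aromatic carbon. Compound 1 already carries this hydroxy group on the same kind of ring and its value sits close to that of compound 3, so no step beyond the scatter is expected here. For compound 4 an estimated step of a 1.3-fold lower number from compound 3 to compound 4 (0.12 log units; within the scatter) gives an expected value of 1000 nM, within a range from 400 nM to 2500 nM.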

Compound 4, half-maximal inhibitory concentration: 11000 nM
Compound 4: middle estimate off by 11-fold (1.04 log units), on the low side, and the stated range ends below it.
By their numbers in this assay, from the lowest: compounds 1 and 3 (each within the scatter of the next); then compound 2; then compound 4.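

In this assay, among these compounds, the single hydroxy group, placed ortho to a large group and para to a methoxycarbonyl group, gives an 8.3-fold higher number from compound 3 to compound 4 (0.92 log units; beyond the scatter) and so clearly weakens inhibition. Among the compounds shown here, the earlier compounds included no pair differing in one place, so this is the first direct reading of any single change, and it shows that this position is sensitive to even one added heavy atom. No measurement shown here accounts for the step. As far as these compounds go, whether an amino group or a fluorine atom at this position would give a similar step remains open. So does the effect of a hydroxy group elsewhere on this ring.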